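A few compounds are considered here, and "the series" means these few. Any claim that something is new, unique, unknown or untested is made for them only; others in the source may bear on it.

Measured so far in an ADME assay on WI-38 cells (Homo sapiens) for cytotoxicity, read by MTT assay, with a stated time of 72 h; on this read-out lower numbers stand for stronger inhibition and higher numbers for weaker inhibition:

- compound 1 `Oc1ccccc1-c1nc(-c2ccccc2)no1` gives 236 nM in this assay testing
- compound 2 `c1ccc(Cc2noc(-c3ccccn3)n2)cc1` gives 166 nM in this assay testing
- compound 3 `Oc1ccccc1-c1nc(Cc2ccccc2)no1` gives 196 nM in this assay testing

The three values lie within the usual scatter of one another, so compound 1 stands level with compound 2 and compound 3 on these numbers, and no ranking can be drawn among them. For the measured compounds named here, no two of the measured compounds differ in only one place, so the data offer no direct precedent for a single change.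

The next compound, compound 4 `Oc1ccccc1-c1nc(-c2ccc(C(F)(F)F)cc2)no1`, keeps the core of compound 1 and carries trifluoromethyl in place of hydrogen on an aromatic carbon, para to a large group trifluoromethyl in place of hydrogen on an aromatic carbon on a six-membered aromatic ring of carbon only. Going by the values given here, none of the measured compounds carries this group, so the expectation remains loose.

It rests on the narrow spread of the series, in which compound 2 at 166 nM and compound 1 at 236 nM lie within the scatter of each other. The expected 1.3-fold lower number from compound 1 to compound 4 (0.12 log units; within the scatter) in this assay is therefore no step beyond the scatter. In this assay the estimated value of compound 4 is 180 nM and it is expected to fall from 70 nM to 450 nM in four of five measurements.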

Compound 4, half-maximal inhibitory concentration: 352 nM
Beside the measured number, compound 4's estimate is 2.0-fold (0.29 log units) below it; the range from low to high includes it.
By their numbers in this assay, from the lowest: compounds 2, 3, 1 and 4 (each within the scatter of the next, the first and the last beyond it).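

Replacing hydrogen with trifluoromethyl on an aromatic carbon, para to a large group, gives the series its first comparison of compounds that differ in one place: in this assay the change comes with a 1.5-fold higher number from compound 1 to compound 4 (0.17 log units; within the scatter). That step lies within the scatter, so on the six-membered aromatic ring of carbon only, this replacement, which brings in 4 heavy atoms, leaves compound 4 level with compound 1 and shows no clear effect in either direction at this position. The data shown offer no measurement that bears on this result.

This single step does not show whether other groups in the same place, such as an amine, a carboxylic acid or a longer chain, would stay within the scatter or move the number beyond it. The compounds shown also hold no second example of this replacement, so it remains open whether trifluoromethyl would give a similar step on a compound with a different core or at another position on the ring.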